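Toward compound 4 from a limit in a cytotoxicity assay

The source may report more compounds than this note shows. Statements on the series, on what has been measured and on what is new or still open speak of the compounds shown alone.

Measured in an ADME assay on L929 cells (Mus musculus) for cytotoxicity, read by resazurin assay, with a stated time of 96 h; a lower number here means that less compound is tolerated, a higher number that more compound is tolerated:
- compound 1 `CC(C)c1ccc(OC/C(=N\NC(N)=S)c2ccc(Br)cc2)cc1`: 24600 nM
- compound 2 `NC(=S)N/N=C(\COc1ccccc1Cl)c1ccc(Br)cc1`: 25100 nM
- compound 3 `NC(=S)N/N=C(\COc1cccc(Cl)c1)c1ccc(Br)cc1`: < 50200 nM, a limit and not a number

Compound 3 has no readable number and stands only at the limit of < 50200 nM in this assay, at which 1 of the 3 values shown sits. The next compound, compound 4 `NC(=S)N/N=C(\COc1ccc(I)cc1)c1ccc(Br)cc1`, differs from it as follows: 4-iodophenyl in place of 3-chlorophenyl on an oxygen on a saturated carbon. In words, this is 4-iodophenyl in place of 3-chlorophenyl on an oxygen on a saturated carbon.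

Among the compounds with values here, only one measured step bears directly on this place, and it gives no size: a step that the limit leaves unreadable from compound 2 to compound 3. No direction or size can therefore be carried over from it to this assay. The firmest guide is that compound 1 at 24600 nM and compound 2 at 25100 nM lie within the scatter of each other, although they carry different groups at this place.

The expected change is a step that the limit leaves unreadable from compound 3 to compound 4, with no direction supported by the data. Compound 4 is estimated at 25000 nM, with an expected range from 11000 nM to 50000 nM.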

Compound 4, half-maximal cytotoxic concentration: < 20400 nM
Compound 4 gave a limit, no number (the forecaster's own chance of this, stated with the estimate: 15%); middle value at least 1.2-fold (0.08 log units) away from the limit.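

In this assay compound 4, which carries 4-iodophenyl on an oxygen on a saturated carbon, gives a limit and not a number: the limit of < 20400 nM in this assay, at which 1 of the 4 values shown sits.
Its two readable steps are an at least 1.2-fold lower number from compound 2 to compound 4 (0.09 log units; that floor lies within the scatter) and an at least 1.2-fold lower number from compound 1 to compound 4 (0.08 log units; that floor lies within the scatter), so this place now shows a first sign of a lower number, although neither floor goes beyond the scatter.
The steps that join the two limits cannot be read, so the change from 3-chlorophenyl to 4-iodophenyl still has neither direction nor size.

As far as these compounds go, whether a true number for compound 4 would stand clear of the scatter around compound 1 and compound 2 remains open.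
Also open, from the compounds shown here alone, is how 4-chlorophenyl, which would keep the chlorine of compound 3 while taking the ring placement of compound 4, or 4-aminophenyl would read in this assay.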